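The source may hold more compounds than are shown below. What is called first, only, known or untested is meant among the compounds shown, and "the series" means these compounds.

Measured compounds:
Compound 1, `Cc1c(O)ccc2c1[C@H](Cn1cc(-c3ccc(F)cc3)nn1)[C@@]13CC(=O)[C@@](C)(CC[C@@H]21)C3`, gives > 20000 nM in a functional assay on MCF7 cells (Homo sapiens) for cytotoxicity, read by MTT assay, with a stated time of 4 days (on this read-out lower numbers stand for stronger inhibition and higher numbers for weaker inhibition), which is a limit of the assay.
Compound 2, `C=C1C[C@]23C[C@@]1(O)CC[C@H]2c1ccc(OS(=O)(=O)c2ccc(C)cc2)c(C)c1[C@@H]3Cn1cc(-c2ccc(F)cc2)nn1`, gives > 20000 nM, also a limit of the assay.
Compound 3, `C=C1C[C@]23C[C@@]1(O)CC[C@@H]2c1cccc(C)c1[C@@H]3Cn1cc(-c2ccc(Cl)cc2)nn1`, gives > 20000 nM, again a limit of the assay.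

Compound 3 therefore stands where everything measured here stands: at the limit of > 20000 nM in this assay, at which 3 of the 3 values shown sit. Among the compounds with values here, no number separates it from compound 1 or compound 2, and no step between measured compounds can be read from these figures. Compound 4, `C=C1C[C@]23C[C@@]1(O)CC[C@@H]2c1cccc(C)c1[C@@H]3Cn1cc(-c2ccccc2)nn1`, is compound 3 with hydrogen in place of chloro on an aromatic carbon. Within the data shown here, with no measured step to draw on, the removal of the chlorine is expected to shift the read-out, if at all, by no more than the usual scatter, with no direction that can be called. The expected step is a step that the limit leaves unreadable from compound 3 to compound 4. Since compound 3 gives only a limit, compound 4 is expected most likely to return a limit as well rather than a number. In this assay compound 4 is estimated at about 30000 nM, with a range from 10000 nM to 100000 nM.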

Compound 4, half-maximal inhibitory concentration: > 20000 nM
Compound 4: only a limit was reported (the forecaster's own chance of this, stated with the estimate: 85%); the middle value is on the limit's open side.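

In this assay compound 4 gives > 20000 nM as a limit of the assay. No step can be read between compound 3 and compound 4 because both sit at that limit: the limit of > 20000 nM in this assay, at which 4 of the 4 values shown sit. The compounds shown leave open whether the change from 4-chlorophenyl to phenyl alters the read-out at all, and what actual number lies behind each limit.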